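The source may hold more compounds than are shown below. What is called first, only, known or untested is meant among the compounds shown, and "the series" means these compounds.

Compound 1, with the structure `NS(=O)(=O)c1ccc(Nc2nc(N/N=C/c3ccc(C(F)(F)F)cc3)nc(Nc3ccccc3)n2)cc1`, carries a 4-(trifluoromethyl)phenyl on the carbon doubly bonded to nitrogen, and in a functional assay on OVCAR-5 cells (Homo sapiens) for inhibition, read by sulforhodamine B assay, with a stated time of 48 h (a higher number here means that more compound is tolerated, a lower number that less compound is tolerated), compound 1 gives 39900 nM. Compound 2, with the structure `Cc1nn(-c2ccccc2)cc1/C=N/Nc1nc(Nc2ccccc2)nc(Nc2ccc(S(N)(=O)=O)cc2)n1`, differs from it only in that place. In this assay compound 2 is reported only as a limit, > 100000 nM, and not as a number. One of the two values shown therefore sits at the limit of > 100000 nM in this assay, at which 1 of the 2 values shown sits. The measured step is an at least 2.5-fold higher number from compound 1 to compound 2 (0.39 log units; beyond the scatter), so compound 2 stands at the upper edge of what the assay can report, and its true value is known only as being somewhere past that edge.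

Compound 3, with the structure `NS(=O)(=O)c1ccc(Nc2nc(N/N=C/c3ccccn3)nc(Nc3ccccc3)n2)cc1`, is not yet measured. It differs from compound 2 by pyridin-2-yl in place of 3-methyl-1-phenyl-1H-pyrazol-4-yl on a carbon with a double bond to nitrogen. Among the measured compounds shown here, the only measured step that touches this position is the one from compound 1 to compound 2, where a change at the same place moved the number beyond the limit. For the measured compounds named here, the new group is smaller than either of the two measured ones, and no measured step tells which way that pulls. Compound 3 is therefore expected to sit roughly where compound 1 and compound 2 do, an estimated 60000 nM in this assay, within a range of 15000 nM to 100000 nM, which would mean an expected step of an at least 1.6-fold lower number from compound 2 to compound 3 (0.22 log units; that floor lies within the scatter).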

Compound 3, concentration lethal to 50% of the cells: > 100000 nM
Compound 3 was reported as a limit; the forecaster's own chance of this, stated with the estimate: 45%; at least 1.6-fold (0.22 log units) between middle value and limit.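

Replacing the 4-(trifluoromethyl)phenyl of compound 1 with pyridin-2-yl gives an at least 2.5-fold higher number from compound 1 to compound 3 (0.39 log units; beyond the scatter) in this assay, so a second, quite different group on this carbon also moves the number beyond the scatter in the same direction. The pyridin-2-yl that enters has fewer heavy atoms than the 3-methyl-1-phenyl-1H-pyrazol-4-yl that leaves, yet this large difference in group size at this place does not bring compound 3 back under the limit. The step from compound 2 to compound 3 cannot be read, because both compounds are reported only as limits and any difference between them stays hidden at the edge of what the assay reports: the limit of > 100000 nM in this assay, at which 2 of the 3 values shown sit.

Compound 1, with 39900 nM, is the only compound shown with a true number, so 4-(trifluoromethyl)phenyl is the only group here known to give a value within the range of this assay. Going by these compounds, it remains open whether that value depends on the trifluoromethyl itself, or whether a plain phenyl, a 4-methoxyphenyl or a pyridin-4-yl on the same carbon would also give a number.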